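The source may report more compounds than this note shows. Statements on the series, on what has been measured and on what is new or still open speak of the compounds shown alone.

- compound 1 `O=C(NNc1ccccc1Cl)c1ccc(NS(=O)(=O)c2cnc(O)nc2O)cc1`: 4010 nM
- compound 2 `O=C(NNc1cccc(Cl)c1)c1ccc(NS(=O)(=O)c2cnc(O)nc2O)cc1`: 17400 nM
- compound 3 `CCCCOc1ccc(C(=O)NNC(=O)c2ccc(NS(=O)(=O)c3cnc(O)nc3O)cc2)cc1`: 11900 nM

These numbers come from a functional assay on MDA-MB-231 cells (Homo sapiens) for antiproliferative activity, read by MTT assay, with a stated time of 24 h; on this read-out higher numbers stand for weaker inhibition and lower numbers for stronger inhibition. Compound 3 lies within the scatter of compound 2, so the two cannot be told apart here. Both give a higher number, meaning weaker inhibition, than compound 1.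

The next compound to be tested is compound 4 `Cc1ccc(C(=O)NNC(=O)c2ccc(NS(=O)(=O)c3cnc(O)nc3O)cc2)cc1`. It differs from compound 3 at a single place: methyl in place of butoxy on an aromatic carbon. In words, this is methyl in place of butoxy on an aromatic carbon, para to a large group.

Within the data shown here, no measured step makes this same change. Among the measured compounds shown here, the only step available is a 4.3-fold higher number from compound 1 to compound 2 (0.64 log units; beyond the scatter), and it concerns 3-chlorophenyl in place of 2-chlorophenyl on an amine nitrogen, a different change at a different place. That modest step shows that one small edit can move the number beyond the scatter, but it offers no direction for this one. The expectation in this assay is therefore no clear shift, and the estimated step is a 1.2-fold lower number from compound 3 to compound 4 (0.08 log units; within the scatter). The range stays wide to allow for a modest move either way.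

For compound 4 the expected value is 10000 nM. The estimated range runs from 3500 nM to 28000 nM.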

Compound 4, half-maximal inhibitory concentration: > 20000 nM
Compound 4: a limit, no number; the forecaster's own chance of this, stated with the estimate: 4%; at least 2.0-fold (0.30 log units) between middle value and limit.
By their numbers in this assay, from the lowest: compound 1; then compounds 3 and 2 (each within the scatter of the next). At a limit, above all of these: compound 4.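

Compound 4 carries a limit of the assay rather than a number: the limit of > 20000 nM in this assay, at which 1 of the 4 values shown sits.

At this position, on an aromatic carbon para to a large group, replacing butoxy with methyl brings no gain in this assay, since the change gives an at least 1.6-fold higher number from compound 3 to compound 4 (0.22 log units; that floor lies within the scatter). That floor is too small to prove a real loss, and the same caution applies to the comparison with the 3-chlorophenyl compound, which shows an at least 1.1-fold higher number from compound 2 to compound 4 (0.06 log units; that floor lies within the scatter). The clear result is the gap to the 2-chlorophenyl compound, an at least 4.9-fold higher number from compound 1 to compound 4 (0.69 log units; beyond the scatter), so the 4-methylphenyl compound does not approach the strongest inhibition seen in this small set.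

Going by these compounds, because compound 4 has only a limit, how far its true value lies from that of compound 3 remains unknown, and so does whether the change causes any real loss. With only butoxy and methyl to compare at this place, it is also unclear whether chain length or the oxygen matters, and a methoxy group, a longer chain, an amine or a carboxylic acid there could help separate those two possibilities.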